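The compounds below may be only part of what the source reports. "The series", "measured", "known", "first", "only" and "open" are said of these compounds alone.

In a functional assay on HepG2 cells (Homo sapiens) for cytotoxicity, read by MTT assay, with a stated time of 48 h (on this read-out higher numbers stand for weaker inhibition and lower numbers for stronger inhibition), compound 1 `CN(C)CCCNc1ccnc2cc(OCc3ccc(F)cc3)ccc12` gives 1570 nM. Compound 2 `Fc1ccc(COc2ccc3c(Cl)ccnc3c2)cc1` gives 3010 nM in this assay, and compound 3 `C=CCOc1ccc2c(NCCCN(C)C)ccnc2c1` gives 3990 nM. The difference between compound 1 and compound 2 is chloro in place of (3-(dimethylamino)propyl)amino on an aromatic carbon, and this change made a step of a 1.9-fold higher number from compound 1 to compound 2 (0.28 log units; within the scatter). The cores of compound 1 and compound 3 differ in one place, as follows: vinyl in place of 4-fluorophenyl on a saturated chain carbon bound to an oxygen on an aromatic ring. That change made a step of a 2.5-fold higher number from compound 1 to compound 3 (0.41 log units; beyond the scatter). Compound 3 stands at the highest of the three numbers, though its gap to compound 2 is within the scatter.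

Compound 4 `C=CCOc1ccc2c(Cl)ccnc2c1` has not yet been measured in this assay. It differs from compound 3 as follows: chloro in place of (3-(dimethylamino)propyl)amino on an aromatic carbon. The place of this change reads the same, word for word, as the place of the change between compound 1 and compound 2, so it is the same change, made a second time on the other core. The step for compound 4 is expected to be a 1.9-fold higher number from compound 3 to compound 4 (0.28 log units; within the scatter), an expectation resting on the earlier step of a 1.9-fold higher number from compound 1 to compound 2 (0.28 log units; within the scatter). The estimate for compound 4 is 7600 nM, expected to fall between 3500 nM and 16000 nM.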

Compound 4, half-maximal inhibitory concentration: 2770 nM
Estimate against measurement, compound 4: 2.7-fold (0.44 log units) above; measured number below the stated range.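

In this assay, putting chloro in place of (3-(dimethylamino)propyl)amino gave a 1.4-fold lower number from compound 3 to compound 4 (0.16 log units; within the scatter), and this step does not match the one seen for the same change on the core of compound 1: the same change on two cores in this assay, a 1.9-fold higher number (0.28 log units; within the scatter) from compound 1 to compound 2 and a 1.4-fold lower number (0.16 log units; within the scatter) from compound 3 to compound 4, 2.8-fold (0.44 log units) apart, beyond the scatter of two such steps Each step taken alone lies within the scatter, so neither core by itself shows that the change moves the number, and only the gap between the two steps lies beyond it. With a single pair on each core, this shows that the step on one core was a poor guide to the step on the other, but it does not show why, or how the change would behave on a further core.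

The compounds shown carry only chloro or (3-(dimethylamino)propyl)amino at the changing place, and only vinyl or 4-fluorophenyl on the chain carbon bound to the oxygen. From the compounds shown here alone, it remains open whether a different amine, such as a morpholine, or a longer chain ending in an amine would follow either step.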